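Notes on the step from compound 1 to compound 4

The source may hold more compounds than are shown below. What is called first, only, known or untested is meant among the compounds shown, and "the series" means these compounds.

Among the measured compounds shown here, compound 1 `Nc1ccccc1NC(=O)c1ccc(CSC(=S)N2CCN(c3ccc(F)cc3)CC2)cc1` stands highest of the three values measured so far in a functional assay on HeLa cells (Homo sapiens) for antiproliferative activity, read by CCK-8 assay, with a stated time of 72 h, tested at 2 uM (a higher number here means a stronger effect of the compound at the concentration tested, a lower number a weaker effect), where compound 1 gives 60.8%. Compound 3 `Nc1ccccc1NC(=O)c1ccc(CSC(=S)N2CCCC2)cc1` gives 51.3%, a value within the scatter of compound 1, so no order between the two can be read. Compound 2 `CN(C(=S)SCc1ccc(C(=O)Nc2ccccc2N)cc1)c1cccnc1` gives 16%, well below both. For the measured compounds named here, the only measured step, a number 35.3 percentage points higher from compound 2 to compound 3 (beyond the scatter), changes the group on the thiocarbonyl carbon and says nothing about the aryl fluorine. Compound 4 `Nc1ccccc1NC(=O)c1ccc(CSC(=S)N2CCN(c3ccccc3)CC2)cc1` differs from compound 1 in one place: hydrogen in place of fluoro on an aromatic carbon. Going by the values given here, no measured pair bears on this change, so no step beyond the scatter is expected in this assay. The step expected is a number 3.8 percentage points lower from compound 1 to compound 4 (within the scatter). Compound 4 is estimated at 57%, between 44% and 70%.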

Compound 4, a percentage reported as inhibition, at one concentration (the size of the read-out at that concentration, not a potency): 62.2%
Beside the measured number, compound 4's estimate is 5.2 percentage points below it; measured number inside the range.
By their numbers in this assay, from the lowest: compound 2; then compounds 3, 1 and 4 (each within the scatter of the next, the first and the last beyond it).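

In this assay the change from 4-fluorophenyl to phenyl gives a number 1.4 percentage points higher from compound 1 to compound 4 (within the scatter) and so sets no order between the two compounds. At this place, para to a large group, the fluoro is not required to keep the read-out at the single concentration tested, since hydrogen serves equally well there. No measurement here bears on why the change leaves the read-out in place.

Still open, from the compounds shown here alone, is whether a larger group at this place, such as methoxy, trifluoromethyl or an amine, would move the number beyond the scatter. A read-out at one concentration also leaves any difference in potency between the two compounds unresolved.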